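An Aryl Swap on the Saturated Ring Carbon

The source may hold more compounds than are shown below. What is called first, only, known or untested is meant among the compounds shown, and "the series" means these compounds.

Compound 2 `COc1cc(/C=C/C(=O)C2=C(/C=C/c3ccc(O)c(OC)c3)NC(=O)NC2c2ccccc2O)ccc1O` stands highest of the two numbers in a functional assay, with a stated time of 20 min, tested at 2 uM (on this read-out higher numbers stand for a stronger effect at the one concentration tested and lower numbers for a weaker effect), where compound 2 gives 33.6%. Its nearest neighbour is compound 1 `COc1cc(/C=C/C(=O)C2=C(/C=C/c3ccc(O)c(OC)c3)NC(=O)NC2c2ccc(C)cc2)ccc1O`, which in this assay gives 17.2%. Among the measured compounds shown here, the single measured step, a number 16.4 percentage points higher from compound 1 to compound 2 (beyond the scatter), changed the group on the same saturated ring carbon and so bears on the change ahead. Compound 3 `COc1cc(/C=C/C(=O)C2=C(/C=C/c3ccc(O)c(OC)c3)NC(=O)NC2c2ccc(N(C)C)cc2)ccc1O` differs from compound 2 by 4-(dimethylamino)phenyl in place of 2-hydroxyphenyl on a saturated ring carbon. For the measured compounds named here, with only that one modest step as a guide, the expectation is a modest drop, a number 11.6 percentage points lower from compound 2 to compound 3 (beyond the scatter). Compound 3 is therefore expected to give 22%, within 8% to 38%.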

Compound 3, a percentage reported as activity, at one concentration (the size of the read-out at that concentration, not a potency): 17.9%
Compound 3: middle estimate off by 4.1 percentage points, on the high side; low and high end bracket the measured number.
By their numbers in this assay, from the lowest: compounds 1 and 3 (each within the scatter of the next); then compound 2.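

At this saturated ring carbon, 4-(dimethylamino)phenyl in place of 2-hydroxyphenyl gives a number 15.7 percentage points lower from compound 2 to compound 3 (beyond the scatter) and shows that a second aryl group also falls short of compound 2. Dimethylamino in place of methyl on an aromatic carbon gives a number 0.7 percentage points higher from compound 1 to compound 3 (within the scatter) and so does not separate those two groups on this read-out. No evidence here accounts for the standing of the 2-hydroxyphenyl group. Still open, from the compounds shown here alone, is how 2-methoxyphenyl or 4-hydroxyphenyl would read at this carbon, and so whether the hydroxyl group or its place on the aromatic ring matters.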